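Carbamoyl swap on the shared core: working notes

A few compounds are considered here, and "the series" means these few. Any claim that something is new, unique, unknown or untested is made for them only; others in the source may bear on it.

Compound 1 `N#Cc1c(Nc2ccccn2)nc(SCc2nc3ccccc3[nH]2)nc1-c1ccccc1` gives 2.8 nM
Compound 2 `N#Cc1c(NC(N)=S)nc(SCc2nc3ccccc3[nH]2)nc1-c1ccccc1` gives 3.37 nM

In a functional assay on NCI-H460 cells (Homo sapiens) for cytotoxicity, read by MTT assay, with a stated time of 3 days (on this read-out lower numbers stand for stronger inhibition and higher numbers for weaker inhibition), compound 2 gives 3.37 nM and lies within the scatter of compound 1, the only other measured point. Compound 3 `N#Cc1c(NC(N)=O)nc(SCc2nc3ccccc3[nH]2)nc1-c1ccccc1` carries one change, (a group of 3 heavy atoms (1 carbon, 1 nitrogen, 1 oxygen; no ring) in place of a group of 3 heavy atoms (1 carbon, 1 nitrogen, 1 sulfur; no ring), on a nitrogen on an aromatic ring), with carbamoyl entering. For the measured compounds named here, one measured step bears on it, at the same nitrogen: a 1.2-fold higher number from compound 1 to compound 2 (0.08 log units; within the scatter). Going by the values given here, no measured step covers this exact exchange, so that single step sets the expectation of no shift beyond the scatter in this assay. The expected step is a 1.2-fold higher number from compound 2 to compound 3 (0.07 log units; within the scatter). For compound 3 the estimated value is 4 nM, with an expected range from 1.3 nM to 14 nM.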

Compound 3, half-maximal inhibitory concentration: 14.7 nM
Compound 3: middle estimate off by 3.7-fold (0.57 log units), on the low side; the whole stated range lies below it.
By their numbers in this assay, from the lowest: compounds 1 and 2 (each within the scatter of the next); then compound 3.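

In this assay, this nitrogen on an aromatic ring no longer looks indifferent to its substituent: carbamoyl with oxygen in place of sulfur gives a 4.4-fold higher number from compound 2 to compound 3 (0.64 log units; beyond the scatter), although the counted donors and acceptors stay the same. Carbamoyl also separates from pyridin-2-yl, with a 5.3-fold higher number from compound 1 to compound 3 (0.72 log units; beyond the scatter), whereas the earlier step between pyridin-2-yl and the sulfur group stayed within the scatter. Nothing available here accounts for the shift. From the compounds shown here alone, whether a free amine or an acetyl group on this nitrogen would fall near compound 2 or near compound 3 remains open.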